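Fluoro added to the bromophenyl ring of compound 2

This account rests on a few compounds, and the source may have more. Where it says the series, first, only, none or still open, it means among the compounds named here.

Among the measured compounds shown here, compound 2 `Cn1ccc2c(Oc3ccc(NC(=O)c4nn(-c5ccc(Br)cc5)ccc4=O)cc3)ccnc21` is the only compound of the pair with a number in a functional assay on A549 cells (Homo sapiens) for cytotoxicity, read by MTT assay, with a stated time of 72 h; a lower number here means a stronger inhibitor, a higher number a weaker inhibitor: compound 2 gives 59400 nM. Compound 1 `COc1ccc(-n2ccc(=O)c(C(=O)Nc3ccc(Oc4ccnc5c4ccn5C)cc3)n2)cc1` gives > 60000 nM in this assay, a limit of the assay (the limit of > 60000 nM in this assay, at which 1 of the 2 values shown sits). The step of a number no higher from compound 1 to compound 2 (the limit leaves the size open) concerns another ring. Compound 3 `Cn1ccc2c(Oc3ccc(NC(=O)c4nn(-c5ccc(Br)cc5F)ccc4=O)cc3)ccnc21` carries fluoro in place of hydrogen on an aromatic carbon, on an aromatic carbon of a six-membered aromatic ring of carbon only, ortho to a large group and meta to a bromo group. For the measured compounds named here, no measured step bears on this change. Given that compound 2 gives 59400 nM, compound 3 is expected at 50000 nM, within 20000 nM to 60000 nM. The expected step of a 1.2-fold lower number from compound 2 to compound 3 (0.07 log units; within the scatter) stays within the scatter.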

Compound 3, half-maximal inhibitory concentration: 35700 nM
Estimate against measurement, compound 3: 1.4-fold (0.15 log units) above; low and high end bracket the measured number.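

In this assay, fluoro at this ring carbon, ortho to a large group and meta to the bromo group, gives a 1.7-fold lower number from compound 2 to compound 3 (0.22 log units; within the scatter), so this change on the 4-bromophenyl ring cannot be told from the scatter. The change from 4-methoxyphenyl to 4-bromo-2-fluorophenyl on the aromatic nitrogen gives an at least 1.6-fold lower number from compound 1 to compound 3 (0.22 log units; that floor lies within the scatter). That step is only a floor, as the value of compound 1 is a limit: the limit of > 60000 nM in this assay, at which 1 of the 3 values shown sits.

On these data alone, whether an amine, a carboxylic acid or a longer chain at this ring carbon would give a step beyond the scatter remains open.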